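The source may report more compounds than this note shows. Statements on the series, on what has been measured and on what is new or still open speak of the compounds shown alone.

Measured compounds in the series:

Compound 1 `CC1(C)C(=O)N(c2ccc(S(C)(=O)=O)cc2)c2ncccc21` gives 0% in a functional assay on the whole organism (Pleural cavity) for inhibition, with Rattus norvegicus as the target, at a dose of 25 mg/kg; a higher number here means more inhibition at the dose given (going by the name of the read-out), a lower number less inhibition.
Compound 2 `CSc1ccc(N2C(=O)C(C)(C)c3cccnc32)cc1` gives 37% in this assay.
Compound 3 `CCCCC1(C)C(=O)N(c2ccccc2)c2ncccc21` gives 5% in this assay.

Compound 2 stands highest of the three numbers; its margin over compound 3 and over compound 1 is in each case beyond the scatter, so its number is the highest of the measured set. Among the compounds with values here, the one single-point step recorded, a number 37 percentage points higher from compound 1 to compound 2 (beyond the scatter), shows that exchanging the group on the aromatic carbon has a large effect.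

Compound 4 `CC(C)c1ccc(N2C(=O)C(C)(C)c3cccnc32)cc1` is the next member to be measured. It differs from compound 2 by isopropyl in place of methylsulfanyl on an aromatic carbon. Within the data shown here, no measured step involves isopropyl, so the step from compound 1 to compound 2 is the only one that bears on a change at this position, and it says only that the read-out is sensitive there, not in which direction an isopropyl will move it. Compound 3, carrying a butyl chain and an unsubstituted phenyl, differs in two places and gives no direct guidance. The expectation for compound 4 is therefore a drop from compound 2, a number 12 percentage points lower from compound 2 to compound 4 (beyond the scatter), with wide uncertainty. Compound 4 is estimated at 25%, within 3% to 50%.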

Compound 4, a percentage reported as inhibition, in the whole organism at one dose (the size of the read-out at that dose, not a potency): 6%
Compound 4: the middle estimate sits 19 percentage points above what was measured; low and high end bracket the measured number.
By their numbers in this assay, from the lowest: compounds 1, 3 and 4 (each within the scatter of the next); then compound 2.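

On an aromatic carbon para to a large group, isopropyl in place of methylsulfanyl brings a number 31 percentage points lower from compound 2 to compound 4 (beyond the scatter) in this assay and so the read-out of compound 2 does not survive this change. Isopropyl in place of methylsulfonyl gives a number 6 percentage points higher from compound 1 to compound 4 (within the scatter) and so these two groups cannot be told apart here, which leaves methylsulfanyl alone among the three groups tried at this place on the shared core. Nothing on hand explains why methylsulfanyl stands apart.

Open, on these data alone, is whether the sulfur or the whole methylsulfanyl group carries the read-out: methoxy or ethylsulfanyl at this place would test that. Also open, as far as these compounds go, is where a bare phenyl on the core of compound 2 would fall.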